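The compounds below may be only part of what the source reports. "The series", "measured", "known", "first", "only" and "open" are said of these compounds alone.

Compound 1 `CC1=C(C(=O)Nc2ccc([N+](=O)[O-])cc2)C(c2ccc(Br)cc2)N=C(SCc2cccc(Cl)c2)N1` gives 2.6% in a functional assay on the whole organism (artery, strain albino) with Rattus norvegicus as the target, with a stated time of 30 min, at a dose of 10 mg/kg by the oral route; a lower number here means less inhibition, a higher number more inhibition at the dose given (going by the name of the read-out).
Compound 2 `CC1=C(C(=O)Nc2ccc([N+](=O)[O-])cc2)C(c2ccc(Br)cc2)N=C(SCc2ccc(Cl)cc2)N1` gives 6.2% in this assay.
Compound 3 `CC1=C(C(=O)Nc2ccc([N+](=O)[O-])cc2)C(c2ccc(Br)cc2)N=C(SCc2ccc(F)cc2)N1` gives 5.2% in this assay.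

Compound 3 stands close to both others: the gap a number 1 percentage points lower from compound 2 to compound 3 (within the scatter) and the gap a number 2.6 percentage points higher from compound 1 to compound 3 (within the scatter) are each within the scatter, so the three numbers are not separable. Compound 4 `CC1=C(C(=O)Nc2ccc([N+](=O)[O-])cc2)C(c2cccc([N+](=O)[O-])c2)N=C(SCc2ccc(F)cc2)N1` is unmeasured; the change is 3-nitrophenyl in place of 4-bromophenyl on a saturated ring carbon. For the measured compounds named here, no measured step touches this saturated ring carbon. The steps on record, a number 3.6 percentage points higher from compound 1 to compound 2 (within the scatter), a number 2.6 percentage points higher from compound 1 to compound 3 (within the scatter) and a number 1 percentage points lower from compound 2 to compound 3 (within the scatter), all vary the (4-fluorobenzyl)sulfanyl side and all lie within the scatter, so they say nothing about a 3-nitrophenyl here. The expectation for compound 4 is therefore a step of a number 0.2 percentage points lower from compound 3 to compound 4 (within the scatter), no change beyond the scatter. Compound 4 is expected at 5%, between 0% and 15%.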

Compound 4, a percentage reported as inhibition, in the whole organism at one dose (the size of the read-out at that dose, not a potency): 4.1%
For compound 4 the middle estimate is 0.9 percentage points above the measured one; measured number inside the range.
By their numbers in this assay, from the lowest: compounds 1, 4, 3 and 2 (each within the scatter of the next).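

For the compounds shown here, this is the first step at the saturated ring carbon: in this assay the change gives a number 1.1 percentage points lower from compound 3 to compound 4 (within the scatter). The 3-nitrophenyl brings in two hydrogen-bond acceptors that the 4-bromophenyl lacks, yet the two compounds are not separated at this dose. Nothing on record speaks to the reason for this result.

On these data alone, whether a phenyl ring carrying an amine or a carboxylic acid at this carbon, or a longer chain in its place, would move the number beyond the scatter stays open. So does the role of the amide side, identical in all four compounds.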